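Series notes: one ring chloro removed from compound 2

A few compounds are considered here, and "the series" means these few. Any claim that something is new, unique, unknown or untested is made for them only; others in the source may bear on it.

Three compounds have numbers in a functional assay on NCI-H226 cells (Homo sapiens) for cytotoxicity, read by sulforhodamine B assay, with a stated time of 48 h; a higher number here means a weaker inhibitor of growth, a lower number a stronger inhibitor of growth. Compound 2 `ClCc1ccc(Cn2cnc3nc(Cl)nc(Cl)c32)cc1` gives 1230 nM, the lowest of the three. Compound 1 `ClCc1cccc(Cn2cnc3ncnc(Cl)c32)c1` gives 3160 nM, and compound 3 `ClCc1cccc(Cn2cnc3c(Cl)nc(Cl)nc32)c1` gives 3230 nM; each of these lies beyond the scatter from compound 2, while the two of them lie within the scatter of each other. Going by the values given here, no pair of measured compounds differs in a single place, so no step size in this assay is fixed by measurement.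

Compound 4 `ClCc1ccc(Cn2cnc3ncnc(Cl)c32)cc1` has not been measured. It differs from compound 2 by hydrogen in place of chloro on an aromatic carbon. Among the compounds with values here, with no measured single-change step to lean on, the expectation is a step from compound 2 to compound 4 of no size beyond the scatter in this assay, in either direction, so the estimated step is a 1.2-fold higher number from compound 2 to compound 4 (0.09 log units; within the scatter). For compound 4 the estimated value in this assay is 1500 nM, with a range from 600 nM to 4000 nM.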

Compound 4, concentration for 50% growth inhibition: 3010 nM
Estimate against measurement, compound 4: 2.0-fold (0.30 log units) below; measured number inside the range.
By their numbers in this assay, from the lowest: compound 2; then compounds 4, 1 and 3 (each within the scatter of the next).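

Going by these compounds alone, the chloro on the aromatic carbon between two ring nitrogen atoms now has a measured single-change step in this assay: replacing it with hydrogen gives a 2.4-fold higher number from compound 2 to compound 4 (0.39 log units; beyond the scatter), a modest change and the first such step. Without this chloro, compound 4 sits within the scatter of compound 1, which also carries hydrogen on this carbon, so compound 2 stands alone with the lowest number of the four. Nothing available explains the size of this step.

From the compounds shown here alone, whether an amine or a methoxy group on this carbon would give a number nearer to compound 2 or to compound 4 remains open. So does whether the chloro counts to the same extent when the chloromethyl group sits where it does in compound 1.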